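A few compounds are considered here, and "the series" means these few. Any claim that something is new, unique, unknown or untested is made for them only; others in the source may bear on it.

Working notes on the series. Compound 1 `Cc1c(OCCCCOc2ccccc2C(=O)O)ccc(C(=O)CC2CCCC2)c1C` gives 67.1% in an assay on HEK293 cells for positive allosteric modulation of metabotropic glutamate receptor 2 (Rattus norvegicus), read by thallium flux, with a stated time of 2.5 min; on this read-out higher numbers stand for larger maximal responses and lower numbers for smaller maximal responses. Compound 2 `Cc1c(OCCCCOc2ccccc2C(=O)O)ccc(C(=O)CC(C)C)c1O` gives 92.4% in this assay, and compound 3 `Cc1c(OCCCCOc2ccccc2C(=O)O)ccc(C(=O)CC2CCCC2)c1O` gives 98.8% in this assay. Compound 3 thus holds the highest of the three numbers; its gap to compound 2 is within the scatter, so no order between those two is claimed, while its gap to compound 1 lies beyond the scatter. The step with hydroxy in place of methyl on an aromatic carbon gave a number 31.7 percentage points higher from compound 1 to compound 3 (beyond the scatter), and the step with cyclopentyl in place of isopropyl on a saturated chain carbon bound to a carbonyl carbon gave a number 6.4 percentage points higher from compound 2 to compound 3 (within the scatter).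

Compound 4 `Cc1cc(C(=O)O)ccc1OCCCCOc1ccc(C(=O)CC2CCCC2)c(O)c1C` keeps the hydroxy and the cyclopentyl of compound 3 and differs only in the group on an oxygen on a saturated carbon: 4-carboxy-2-methylphenyl in place of 2-carboxyphenyl on an oxygen on a saturated carbon. Neither measured step touches that part of the molecule, so the measured data give no direct guide to the size or direction of this change. Without such a guide the working expectation is a step of a number 8.8 percentage points lower from compound 3 to compound 4 (within the scatter), within the scatter, with wide uncertainty. Compound 4 is therefore expected to give about 90% in this assay, in a range from 60% to 115%.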

Compound 4, largest response reached (reported as percent of maximum), in percent of the reference or control that the assay uses: 84.6%
Compound 4: middle estimate off by 5.4 percentage points, on the high side; the measured number falls inside the stated range.
By their numbers in this assay, from the lowest: compound 1; then compounds 4, 2 and 3 (each within the scatter of the next, the first and the last beyond it).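

Compounds 1 to 3 all carry 2-carboxyphenyl, so they say nothing about the group on an oxygen on a saturated carbon; compound 4 shows that this group does bear on the maximal response in this assay, with 4-carboxy-2-methylphenyl in place of 2-carboxyphenyl giving a number 14.2 percentage points lower from compound 3 to compound 4 (beyond the scatter). The two groups match in their counted hydrogen-bond donors and acceptors and in their single six-membered aromatic ring, and the entering group has one more heavy atom, so this single step combines a different carboxy placement with an added methyl and cannot assign the drop to either. No measurement shown here explains the drop.

Going by these compounds, it remains open whether a carboxyphenyl without the methyl, or a methyl-bearing ring with the carboxy placed as in 2-carboxyphenyl, would account for the step, and whether a tetrazole or a primary amide could stand in for the carboxylic acid at this position. Also open, on these data alone, is whether the step would keep its size with the isopropyl of compound 2 or the aromatic methyl of compound 1 in place of the cyclopentyl or hydroxy of compound 3.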